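The compounds below may be only part of what the source reports. "The series", "measured", "known", "first", "only" and "open" are said of these compounds alone.

In a physicochemical assay for lipophilicity, at pH 7.4 (a higher number here means a more lipophilic compound, a lower number a more polar compound), compound 1 `Cc1cc(C(N)=O)nn1Cc1cc(Cl)ccc1OCc1ccccc1` gives 3.7. Compound 2 `Cc1cc(NC(=O)C(C)C)nn1Cc1cc(Cl)ccc1OCc1ccccc1` carries (isopropylcarbonyl)amino where compound 1 carries carbamoyl, and in this assay compound 2 reports only a limit, > 3.7, rather than a number. The step of a number no lower from compound 1 to compound 2 (the limit leaves the size open) therefore has a direction but no readable size. Compound 3 `Cc1cc(NC(=O)c2c(F)cccc2F)nn1Cc1cc(Cl)ccc1OCc1ccccc1` is reached from compound 2 by a single change: 2,6-difluorophenyl in place of isopropyl on a carbonyl carbon. Within the data shown here, only the one measured step of a number no lower from compound 1 to compound 2 (the limit leaves the size open) bears on this move, and it is cut short by the limit of > 3.7 in this assay, at which 1 of the 2 values shown sits. Because compound 2 already sits at the limit of > 3.7 in this assay, at which 1 of the 2 values shown sits, the number for compound 3 can only be judged upward from there. A rise in this assay is expected for compound 3, by a step that the limit leaves unreadable from compound 2 to compound 3. Compound 3 is expected to give 4.8, within 4 to 5.6, and is very likely to be reported once more only as a limit.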

Compound 3, distribution coefficient: > 3.7
Compound 3: no number, only a limit (the forecaster's own chance of this, stated with the estimate: 85%); the middle value lies beyond the limit too.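

The change from carbamoyl to ((2,6-difluorophenyl)carbonyl)amino gives a number no lower from compound 1 to compound 3 (the limit leaves the size open). This position has now taken both isopropyl and 2,6-difluorophenyl on the carbonyl carbon, and neither amide gives a number in this assay, so all the steps here are unreadable in size. The new amide, with its six-membered aromatic ring, ends at the same point as the smaller isopropyl amide: the limit of > 3.7 in this assay, at which 2 of the 3 values shown sit.

On these data alone, how compound 2 and compound 3 truly compare stays unknown, and the effect of replacing isopropyl with 2,6-difluorophenyl remains without a size. Also open, as far as these compounds go, is whether a carboxylic acid or an amine, carried in place of isopropyl on a carbonyl carbon, would give a number rather than a limit.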